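Ethoxy for ethyl on the carboxy compounds: compound 4

The compounds below may be only part of what the source reports. "The series", "measured", "known", "first", "only" and "open" are said of these compounds alone.

Measured so far:
compound 1 `CCc1ccc2nc(C(=O)Nc3c(F)cc(-c4cccc(F)c4)cc3F)c(C)c(O)c2c1` gives 3.56% in a functional assay on A-375 cells (Homo sapiens) for antiproliferative activity, read by MTT assay, with a stated time of 24 h, tested at 0.41 ug/mL; on this read-out lower numbers stand for a weaker effect and higher numbers for a stronger effect at the one concentration tested
compound 2 `CCOc1ccc2nc(C(=O)Nc3c(F)cc(-c4cccc(F)c4)cc3F)c(C)c(O)c2c1` gives 2.05% in this assay
compound 3 `CCc1ccc2nc(C(=O)Nc3c(F)cc(-c4cccc(F)c4)cc3F)c(C)c(C(=O)O)c2c1` gives 6.13% in this assay

Compound 3 has the highest of the three numbers, but its step from compound 1 a number 2.6 percentage points higher from compound 1 to compound 3 (within the scatter) lies within the scatter, and its value set against that of compound 2 shows no gap beyond the scatter either. Compound 4 `CCOc1ccc2nc(C(=O)Nc3c(F)cc(-c4cccc(F)c4)cc3F)c(C)c(C(=O)O)c2c1` differs from compound 3 by ethoxy in place of ethyl on an aromatic carbon. Within the data shown here, the one step that bears on this is the same exchange on the hydroxy pair, a number 1.5 percentage points lower from compound 1 to compound 2 (within the scatter), which stayed within the scatter. No step beyond the scatter is therefore expected in this assay; the estimated step is a number 1.1 percentage points lower from compound 3 to compound 4 (within the scatter). Compound 4 is expected to give about 5%, in the range 0% to 12%.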

Compound 4, a percentage reported as inhibition, at one concentration (the size of the read-out at that concentration, not a potency): 11.2%
Estimate against measurement, compound 4: 6.2 percentage points below; low and high end bracket the measured number.
By their numbers in this assay, from the lowest: compounds 2, 1, 3 and 4 (each within the scatter of the next).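

Ethoxy in place of ethyl now has a second reading at this position, on the carboxy pair, where the step is a number 5.1 percentage points higher from compound 3 to compound 4 (within the scatter), and in this assay the two readings of this exchange do not separate: the same change on two cores in this assay, a number 1.5 percentage points lower (within the scatter) from compound 1 to compound 2 and a number 5.1 percentage points higher (within the scatter) from compound 3 to compound 4, 6.6 percentage points apart, within the scatter of two such steps. Carboxy in place of hydroxy also has a second reading, a number 9.2 percentage points higher from compound 2 to compound 4 (within the scatter), and its two readings do not separate either: the same change on two cores in this assay, a number 2.6 percentage points higher (within the scatter) from compound 1 to compound 3 and a number 9.2 percentage points higher (within the scatter) from compound 2 to compound 4, 6.6 percentage points apart, within the scatter of two such steps. Neither exchange has yet moved the read-out beyond the scatter, and neither shows a dependence on the other.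

As far as these compounds go, whether an amine or a longer chain at this position would do so remains open. So does whether a primary amide in place of the carboxy group would.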